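A bromophenyl swap on a compound with almost no inhibition

This account rests on a few compounds, and the source may have more. Where it says the series, first, only, none or still open, it means among the compounds named here.

In a functional assay on HL-60 cells (Homo sapiens) for inhibition, read by MTT assay, with a stated time of 48 h, tested at 10 uM (a lower number here means less inhibition of growth, a higher number more inhibition of growth at the concentration tested), compound 3 `Cc1oc2c([C@H]3CCN(C)C[C@H]3O)c(O)cc(O)c2c(=O)c1C(O)c1ccc([N+](=O)[O-])cc1` gives 0% of inhibition, within the scatter of compound 1 `Cc1cc(=O)c2c(O)cc(OCc3ccccc3Br)c([C@H]3CCN(C)C[C@H]3O)c2o1` at 3% of inhibition. Compound 2 `Cc1cc(=O)c2c(O)c(CN3CCCC3)c(O)c([C@H]3CCN(C)C[C@H]3O)c2o1` reaches 38% of inhibition, beyond the scatter from compound 3, which leaves compound 3 together with compound 1 at the low end of this small set.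

The next compound to be tested, compound 4 `Cc1oc2c([C@H]3CCN(C)C[C@H]3O)c(O)cc(O)c2c(=O)c1C(O)c1ccccc1Br`, differs from compound 3 in one group: 2-bromophenyl in place of 4-nitrophenyl on a saturated chain carbon bound to an aromatic carbon and an oxygen on a saturated carbon. Within the data shown here, no pair of measured compounds shows this change, so its size cannot be read directly from the data. Among the measured compounds shown here, compound 1 also carries a 2-bromophenyl group and gives 3% of inhibition, so the one compound with that group offers no hint of a large gain. In this assay no step beyond the scatter is therefore expected, and any small move would be upward, since compound 3 stands at 0% of inhibition. The expected step of a number 6 percentage points higher from compound 3 to compound 4 (within the scatter) is small. The estimate for compound 4 is 6% of inhibition, with an expected range from 0% to 20% of inhibition.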

Compound 4, percent growth inhibition at one concentration: 52%
Estimate against measurement, compound 4: 46 percentage points below, and the stated range ends below it.
By their numbers in this assay, from the lowest: compounds 3 and 1 (each within the scatter of the next); then compound 2; then compound 4.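

In this assay, exchanging the 4-nitrophenyl group for a 2-bromophenyl group gives a number 52 percentage points higher from compound 3 to compound 4 (beyond the scatter), which shows that the number at this position depends strongly on which aryl group it carries. The six-membered aromatic ring of carbon only is present on both sides of the step, so the presence of that ring alone does not settle the outcome; what differs is the 4-nitro arrangement, with 2 hydrogen-bond acceptors, against the 2-bromo arrangement, with none. Nothing in the data explains why the exchange has so large an effect.

With only these two groups at this position, the compounds shown cannot separate the departure of the nitro group from the arrival of the bromine, or the effect of the substituent's identity from that of its place on the ring. A plain phenyl, a 4-bromophenyl or a 2-nitrophenyl on the same carbon would address those questions, and a 2-chlorophenyl would test whether bromine itself is needed.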